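Moving the Acetamide to a Different Ring Position

The source may report more compounds than this note shows. Statements on the series, on what has been measured and on what is new or still open speak of the compounds shown alone.

Compound 1 `CC(=O)Nc1cccc(C2CCN(CCCn3c(-c4ccc(Cl)cc4F)nc4ccccc43)CC2)c1` gives 1 nM in an assay for displacement of a labelled ligand from melanin-concentrating hormone receptor 1 (Homo sapiens), read by fluorescence; on this read-out lower numbers stand for stronger inhibition and higher numbers for weaker inhibition. Compound 2 `CC(=O)Nc1ccccc1C1CCN(CCCn2c(-c3ccc(Cl)cc3)nc3ccccc32)CC1` was run in this assay as well. In this assay compound 2 gives > 6000 nM, which is a limit of the assay rather than a measured number. Compound 2 thus stands at the limit of > 6000 nM in this assay, at which 1 of the 2 values shown sits. Compound 3 `CC(=O)Nc1ccc(C2CCN(CCCn3c(-c4ccc(Cl)cc4)nc4ccccc43)CC2)cc1` keeps the core of compound 2 and carries 4-acetamidophenyl in place of 2-acetamidophenyl on a saturated ring carbon. Within the data shown here, no measured pair shows this exact change, so the expectation rests only on the two values shown. A large gain is expected, an at least 600-fold lower number from compound 2 to compound 3 (2.77 log units; beyond the scatter). Compound 3 is therefore estimated at 10 nM, within a range from 2 nM to 100 nM.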

Compound 3, half-maximal inhibitory concentration: 5380 nM
For compound 3 the middle estimate is 540-fold (2.73 log units) below the measured one; the whole stated range lies below it.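

In this assay compound 3 gives 5380 nM, so 4-acetamidophenyl in place of 2-acetamidophenyl does not on its own bring a low number. The change reads an at least 1.1-fold lower number from compound 2 to compound 3 (0.04 log units; that floor lies within the scatter). Compound 2 is held at a limit of the assay, so this step is only a floor: the limit of > 6000 nM in this assay, at which 1 of the 3 values shown sits.

On these data alone, compound 1 differs from compound 3 in more than one place, so which of those differences matters stays open. Also open, as far as these compounds go, is whether an amine or a carboxylic acid in place of the acetamide would give a different number.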